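The source may report more compounds than this note shows. Statements on the series, on what has been measured and on what is new or still open speak of the compounds shown alone.

Measured so far:
compound 1 `CC(C)C(c1noc(=O)[nH]1)c1ccc(-c2ccc3cccc(F)c3c2)[nH]c1=O` — > 3 h
compound 2 `CCn1ncc2c(F)cc(-c3ccc(C(CC)(CC)c4nnc[nH]4)c(=O)[nH]3)cc21` — > 3 h

In an ADME assay on microsomes from liver (Mus musculus) for metabolic stability (on this read-out lower numbers stand for a shorter-lived compound and higher numbers for a longer-lived compound), compound 1 gives > 3 h, which is a limit of the assay and not a number. Compound 2 likewise gives > 3 h in this assay, again a limit. Compound 1 therefore stands at the top of what has been seen: the limit of > 3 h in this assay, at which 2 of the 2 values shown sit. Among the compounds with values here, no step between two measured compounds is available here, so nothing shows how a change of structure moves the half-life.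

Compound 3 `CC(C)C(Cc1noc(=O)[nH]1)c1ccc(-c2ccc3cccc(F)c3c2)[nH]c1=O` has not yet been measured in this assay. It differs from compound 1 by a group of 7 heavy atoms (3 carbon, 2 nitrogen, 2 oxygen; one five-membered aromatic ring with 3 hetero atoms) in place of a group of 6 heavy atoms (2 carbon, 2 nitrogen, 2 oxygen; one five-membered aromatic ring with 3 hetero atoms), on a saturated chain carbon bound to an aromatic carbon and a saturated chain carbon. Given that compound 1 sits at the limit, the step from compound 1 to compound 3 is expected to be small or none beyond the scatter, a number no higher from compound 1 to compound 3 (the limit leaves the size open). For compound 3 the half-life in this assay is estimated at 3 h, within a range of 1.5 h to 6 h, with a fair chance that the assay again returns only a limit.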

Compound 3, half-life: 2.78 h
Beside the measured number, compound 3's estimate is 1.1-fold (0.03 log units) above it; the range from low to high includes it.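

In this assay, the group of 7 heavy atoms in place of the group of 6 heavy atoms, on a saturated chain carbon bound to an aromatic carbon and a saturated chain carbon, gives an at least 1.0-fold lower number from compound 1 to compound 3 (0.03 log units; that floor lies within the scatter). From the compounds shown here alone, the value of compound 1 is a limit, > 3 h, so this step is only a floor and its true size stays open. Within the data shown here, compound 3 gives 2.78 h, the only value shown for this position that is a number. The limit still holds most of the series: the limit of > 3 h in this assay, at which 2 of the 3 values shown sit.

Going by these compounds, whether a carboxylic acid or an amine on this saturated chain carbon, or a longer chain carrying the same five-membered aromatic ring, would change the half-life stays open. Compound 2 differs from the others in more than one place, so it says nothing about this change.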